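This account rests on a few compounds, and the source may have more. Where it says the series, first, only, none or still open, it means among the compounds named here.

For the measured compounds named here, in an ADME assay on Vero cells (Chlorocebus sabaeus) for cytotoxicity, read by resazurin assay, with a stated time of 72 h (a lower number here means a stronger inhibitor, a higher number a weaker inhibitor), compound 3 (`O=C(CCN1CCN(c2ccc(F)cc2)CC1)c1ccc(F)c(Br)c1`) gives 352000 nM and sits at the upper end of the numbers so far. Compound 1 (`Cc1ccc(C(=O)CCN2CCN(c3ccc(Cl)cc3)CC2)cc1`) gives 184000 nM and these two values lie within the scatter of each other. Going by the values given here, compound 2 (`O=C(CCN1CCN(c2ccc(F)cc2)CC1)c1ccc(Br)cc1`) gives 99500 nM and the only measured single change, a 3.5-fold higher number from compound 2 to compound 3 (0.55 log units; beyond the scatter) in size, separates it from compound 3.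

The next compound is compound 4 (`O=C(CCN1CCN(c2ccc(Cl)cc2)CC1)c1ccc(F)c(Br)c1`). Its difference from compound 3 is chloro in place of fluoro on an aromatic carbon and amounts to 4-fluorophenyl becoming 4-chlorophenyl. Among the compounds with values here, no measured step isolates this swap, since the one step available alters the group on the carbonyl carbon instead. Compound 1 does carry the 4-chlorophenyl group, with 184000 nM as its value, but its carbonyl group also differs from that of compound 3, so it offers only a loose guide. The data therefore give no reason to expect a change beyond the scatter in this assay, with at most a slight lean towards the value of compound 1. The expected step is a 1.4-fold lower number from compound 3 to compound 4 (0.13 log units; within the scatter) and this estimate remains tentative. For compound 4 the estimated value is 260000 nM with an expected range of 120000 nM to 520000 nM on repeated measurement.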

Compound 4, half-maximal inhibitory concentration: 206000 nM
Compound 4: middle estimate off by 1.3-fold (0.10 log units), on the high side; the range from low to high includes it.
By their numbers in this assay, from the lowest: compounds 2, 1, 4 and 3 (each within the scatter of the next, the first and the last beyond it).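

In this assay, the aromatic carbon para to a large group now has its first direct reading: chloro in place of fluoro, which turns 4-fluorophenyl into 4-chlorophenyl, gives a 1.7-fold lower number from compound 3 to compound 4 (0.23 log units; within the scatter), so these two halogens cannot be told apart at this position in this assay. For the compounds shown here, the new compound also gives the first look at the group on the carbonyl carbon with 4-chlorophenyl held constant: 3-bromo-4-fluorophenyl in place of 4-methylphenyl gives a 1.1-fold higher number from compound 1 to compound 4 (0.05 log units; within the scatter), so this swap cannot be told apart from the scatter either. No supporting measurement is available to explain either result.

From the compounds shown here alone, what remains open is whether this position tolerates only a choice between these two halogens or would respond to a quite different group, such as a methoxy group or a nitrile, in a way that goes beyond the scatter. Going by these compounds, it is also open whether the chloro and fluoro compounds would still match with another group on the carbonyl carbon, such as the 4-bromophenyl of compound 2.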